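Aryl swap on the ring amine nitrogen of compound 1

The source may hold more compounds than are shown below. What is called first, only, known or untested is meant among the compounds shown, and "the series" means these compounds.

Compound 1 `Nc1scc(CN2CCN(c3ccc([N+](=O)[O-])cc3)CC2)c1C(=O)c1ccc(Cl)cc1` is the starting point of this step. In a functional assay on CHO cells with adenosine receptor A1 (Homo sapiens) as the target, read by cAMP accumulation and immunoassay, with a stated time of 6 min, tested at 10 uM (a higher number here means a weaker effect of the compound at the concentration tested, a lower number a stronger effect), compound 1 gives -17%, the highest of the three numbers shown. Compound 2 `Nc1scc(CN2CCN(c3ccc(C(F)(F)F)cc3)CC2)c1C(=O)c1cccc(C(F)(F)F)c1` gives -47% and compound 3 `Nc1scc(CN2CCN(c3cccc(F)c3)CC2)c1C(=O)c1cccc(C(F)(F)F)c1` gives -62%; both lie well below compound 1, beyond the scatter.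

The unmeasured compound 4 `Nc1scc(CN2CCN(c3cccc4ccccc34)CC2)c1C(=O)c1ccc(Cl)cc1` differs from compound 1 in one place: naphthalen-1-yl in place of 4-nitrophenyl on an amine nitrogen in a ring.

Among the measured compounds shown here, only one measured step touches the same place, the aryl group on the amine nitrogen in the ring: a number 15 percentage points lower from compound 2 to compound 3 (beyond the scatter). That step exchanged one aryl for another on the same nitrogen and moved the number by a modest amount, though the groups involved differ from those here, and compound 2 and compound 3 also carry a different ketone aryl than compound 1. For the measured compounds named here, no step measures the nitro-to-naphthyl exchange itself, so its direction rests on the general finding that aryl changes at this nitrogen shift the read-out modestly.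

The expectation is therefore a modest downward shift, a number 13 percentage points lower from compound 1 to compound 4 (beyond the scatter), with a wide range. Compound 4 is estimated at -30%, between -60% and 0%.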

Compound 4, a percentage reported as activity, at one concentration (the size of the read-out at that concentration, not a potency): -21%
For compound 4 the middle estimate is 9 percentage points below the measured one; the range from low to high includes it.
By their numbers in this assay, from the lowest: compound 3; then compound 2; then compounds 4 and 1 (each within the scatter of the next).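

In this assay, among the compounds shown here, the exchange of 4-nitrophenyl for naphthalen-1-yl on an amine nitrogen in a ring gives a number 4 percentage points lower from compound 1 to compound 4 (within the scatter) and is the first step at this position read with the ketone aryl of compound 1 held fixed. On this core, removing the nitro group and adding a second six-membered aromatic ring of carbon only therefore leaves the read-out unchanged within the scatter. The earlier aryl exchange, a number 15 percentage points lower from compound 2 to compound 3 (beyond the scatter) on a different ketone aryl, lay beyond the scatter, so an aryl exchange on this nitrogen does not always move the number, and the two steps share no aryl group that would allow them to be tied together.

On these data alone, it remains open whether an unsubstituted phenyl, a pyridine or an aryl bearing a carboxylic acid on this nitrogen would shift the number on the core of compound 1, and whether the naphthalen-1-yl exchange would give the same result with the ketone aryl of compound 2 and compound 3. Nothing measured here explains why this exchange leaves the read-out within the scatter.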